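The source may hold more compounds than are shown below. What is called first, only, known or untested is meant among the compounds shown, and "the series" means these compounds.

Compound 1 `CCOC(=O)c1ccc(NC(=O)C(=O)c2ccccc2NC(C)=O)cc1`: 83 nM
Compound 2 `COC(=O)C[C@H](NC(=O)C(=O)c1ccccc1NC(C)=O)C(=O)OC`: 58 nM
Compound 3 `COC(=O)CCNC(=O)C(=O)c1ccccc1NC(C)=O`: 33 nM

In an assay on mitochondria from liver for inhibition of Amine oxidase [flavin-containing] A (Rattus norvegicus), with a stated time of 60 min (a higher number here means a weaker inhibitor, a lower number a stronger inhibitor), compound 1 gives the highest of the three numbers; compound 2 sits nearest to it, within the scatter, while compound 3 lies beyond it. Among the measured compounds shown here, the one comparison inside the set is a 1.8-fold lower number from compound 2 to compound 3 (0.24 log units; within the scatter), and it concerns a saturated chain carbon rather than the ester carbonyl. Compound 4 `COC(=O)CCCCCNC(=O)c1ccc(NC(=O)C(=O)c2ccccc2NC(C)=O)cc1` differs from compound 1 by (5-(methoxycarbonyl)pentyl)amino in place of ethoxy on a carbonyl carbon. For the measured compounds named here, no measured step touches this carbonyl, so there is no direct guide; the three values span a narrow band, and a large move is not foreseen. Compound 4 is therefore expected to give 80 nM in this assay, between 30 nM and 250 nM. This amounts to an expected 1.0-fold lower number from compound 1 to compound 4 (0.02 log units; within the scatter), no shift beyond the scatter.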

Compound 4, half-maximal inhibitory concentration: 930000 nM
Compound 4: the middle estimate sits 12000-fold (4.07 log units) below what was measured; the whole stated range lies below it.
By their numbers in this assay, from the lowest: compounds 3, 2 and 1 (each within the scatter of the next, the first and the last beyond it); then compound 4.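

In this assay, the carbonyl carbon bound to the aromatic carbon proves highly sensitive to what it carries: (5-(methoxycarbonyl)pentyl)amino in place of ethoxy gives an 11000-fold higher number from compound 1 to compound 4 (4.05 log units; beyond the scatter) at this one place. Among the compounds shown here, none of the earlier steps touched this position, and the only earlier step, a 1.8-fold lower number from compound 2 to compound 3 (0.24 log units; within the scatter), gave no sign of a change this large. Nothing at hand accounts for the size of this step.
The compounds shown leave open whether the new amide nitrogen or the long chain carries the loss. A short ethylamino group or a pentylamino chain without its ester on this carbonyl would separate the two.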